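Ketone chain variation in compound 3: expectation for compound 4

The source may hold more compounds than are shown below. What is called first, only, known or untested is meant among the compounds shown, and "the series" means these compounds.

Measured so far:
compound 1 `Cc1c(OCCCCOc2ccc(C(=O)O)cc2F)ccc(C(=O)CC(C)C)c1O`, 85%
compound 2 `Cc1c(OCCCCOc2cccc(C(=O)O)c2)ccc(C(=O)CC(C)C)c1O`, 84.5%
compound 3 `CC(=O)c1ccc(OCCCCOc2ccc(F)c(C(=O)O)c2)c(C)c1O`, 75.5%

In an assay on HEK293 cells for positive allosteric modulation of metabotropic glutamate receptor 2 (Rattus norvegicus), read by thallium flux, with a stated time of 2.5 min (a higher number here means a larger maximal response, a lower number a smaller maximal response), compound 3 gives the lowest of the three numbers, though the gaps to compound 2 and compound 1 both lie within the scatter. Compound 4 `Cc1c(OCCCCOc2ccc(F)c(C(=O)O)c2)ccc(C(=O)CC(C)C)c1O` differs from compound 3 as follows: isopropyl in place of hydrogen on a saturated chain carbon bound to a carbonyl carbon. Among the measured compounds shown here, no measured step covers this change; the only measured step, a number 0.5 percentage points lower from compound 1 to compound 2 (within the scatter), concerns the carboxyphenyl part and was within the scatter. The isobutylcarbonyl group that compound 4 gains is carried by compound 1, which gives 85%, and by compound 2, which gives 84.5%. On that basis a step of a number 7.5 percentage points higher from compound 3 to compound 4 (within the scatter) is expected, within the scatter. Compound 4 is estimated at 83%, range 70% to 95%.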

Compound 4, largest response reached (reported as percent of maximum), in percent of the reference or control that the assay uses: 84.5%
For compound 4 the middle estimate is 1.5 percentage points below the measured one, within the range that was stated.
By their numbers in this assay, from the lowest: compounds 3, 2, 4 and 1 (each within the scatter of the next).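

In this assay, among the compounds shown here, the step of a number 9 percentage points higher from compound 3 to compound 4 (within the scatter) is the first direct reading of isopropyl in place of hydrogen on a saturated chain carbon bound to a carbonyl carbon, and it does not separate acetyl from isobutylcarbonyl. With isobutylcarbonyl held, the steps of no change at the digits printed from compound 2 to compound 4 (within the scatter) for fluoro in place of hydrogen on an aromatic carbon and a number 0.5 percentage points lower from compound 1 to compound 4 (within the scatter) for 3-carboxy-4-fluorophenyl in place of 4-carboxy-2-fluorophenyl also stay within the scatter. No supporting data bear on these steps. The compounds shown leave open how a cyclopropyl group or a longer chain in place of isopropyl would read, and whether a tetrazole could stand in place of the carboxylic acid.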